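The source may report more compounds than this note shows. Statements on the series, on what has been measured and on what is new or still open speak of the compounds shown alone.

Compound 1 `CNCC(=O)Nc1cc(OC)ccc1C(=O)c1ccc2c(c1)C=CC(C)(C)O2` and compound 2 `COc1ccc(C(=O)c2ccc3c(c2)C=CC(C)(C)O3)c(NC(=O)CN(C)C)c1` share one core, while compound 3 `C=C(c1cc(OC)c(OC)c(OC)c1)c1ccc(OC)cc1NC(=O)CN` and the as yet unmeasured compound 4 `C=C(c1cc(OC)c(OC)c(OC)c1)c1ccc(OC)cc1NC(=O)CNC` share another; the difference between the two cores is not broken down here. In a functional assay on MCF7 cells (Homo sapiens) for antiproliferative activity, read by MTT assay, with a stated time of 48 h (a higher number here means a weaker inhibitor, a lower number a stronger inhibitor), compound 1 gives 1210 nM and compound 2 gives 3560 nM. The change between them is methyl in place of hydrogen on an amine nitrogen, and it made a step of a 2.9-fold higher number from compound 1 to compound 2 (0.47 log units; beyond the scatter). Compound 3 gives 190 nM in this assay, the lowest of the three measured numbers. Compound 4 is reached from compound 3 by methyl in place of hydrogen on an amine nitrogen, the same kind of change, though not the same: in compound 1 the amine nitrogen has two saturated chain carbons as its other neighbours, whereas in compound 3 it has one saturated chain carbon. For the measured compounds named here, since the only measured instance of this kind of change is the step of a 2.9-fold higher number from compound 1 to compound 2 (0.47 log units; beyond the scatter), the expectation for compound 4 rests on that step alone, carried over to a different core. Compound 4 is therefore expected to give about 400 nM, with a likely range from 150 nM to 1200 nM. That estimate means a step of a 2.1-fold higher number from compound 3 to compound 4 (0.32 log units; beyond the scatter).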

Compound 4, half-maximal inhibitory concentration: 240 nM
Compound 4: the middle estimate sits 1.7-fold (0.22 log units) above what was measured; the range from low to high includes it.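

In this assay, methyl in place of hydrogen on the amine nitrogen gave a 1.3-fold higher number from compound 3 to compound 4 (0.10 log units; within the scatter), so on this core the change has no effect that can be told from the scatter. Set beside the step on the other core, the two results cannot be told apart: the same change on two cores in this assay, a 2.9-fold higher number (0.47 log units; beyond the scatter) from compound 1 to compound 2 and a 1.3-fold higher number (0.10 log units; within the scatter) from compound 3 to compound 4, 2.3-fold (0.37 log units) apart, within the scatter of two such steps. For the compounds shown here, this shows that the two cores give no measurable disagreement about this change, but it does not show that the change acts alike on both, since only one pair stands on each core, and the amine nitrogen has different neighbours in the two pairs.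

The compounds shown leave open what a second methyl on the nitrogen of compound 4 would do, which would give the dimethylamino group on this core and a pair closer to the change on the other core. They also leave open whether an ethyl group or a longer chain on that nitrogen would move the number on either core.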